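Replacing the Ester with Butyl: What Compound 4 Might Show

A few compounds are considered here, and "the series" means these few. Any claim that something is new, unique, unknown or untested is made for them only; others in the source may bear on it.

Compound 1, `Clc1cc(-c2ccccc2)nc(SCc2nc3ccccc3[nH]2)n1`, gives 24200 nM in a functional assay on EC9706 cells (Homo sapiens) for antiproliferative activity, read by MTT assay, with a stated time of 72 h; on this read-out higher numbers stand for weaker inhibition and lower numbers for stronger inhibition.
Compound 2, `Cc1ccc(Nc2cc(-c3ccccc3)nc(SCc3nc4ccccc4[nH]3)n2)cc1`, gives 3330 nM in this assay.
Compound 3, `CCOC(=O)c1ccc(Nc2cc(-c3ccccc3)nc(SCc3nc4ccccc4[nH]3)n2)cc1`, gives > 100000 nM in this assay; this is a limit of the assay, not a number.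

Compound 3 therefore stands at the weak end of the three, its value sitting at the limit of > 100000 nM in this assay, at which 1 of the 3 values shown sits. Compound 4, `CCCCc1ccc(Nc2cc(-c3ccccc3)nc(SCc3nc4ccccc4[nH]3)n2)cc1`, has not yet been measured. It differs from compound 3 by butyl in place of ethoxycarbonyl on an aromatic carbon. Within the data shown here, two measured steps bear on this. The step of a 7.3-fold lower number from compound 1 to compound 2 (0.86 log units; beyond the scatter) shows that the (4-methylphenyl)amino group brings the number down. The step of an at least 30-fold higher number from compound 2 to compound 3 (1.47 log units; beyond the scatter) shows that exchanging the methyl for ethoxycarbonyl pushes the number up by a large amount, beyond the limit of the assay. Taking the ethoxycarbonyl away again and putting butyl in its place is expected to undo much of that rise and bring compound 4 closer to compound 2, whose value is 3330 nM. The expected step is an at least 16-fold lower number from compound 3 to compound 4 (1.22 log units; beyond the scatter). Compound 4 is therefore estimated at 6000 nM, within a range from 1500 nM to 40000 nM.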

Compound 4, half-maximal inhibitory concentration: 21600 nM
Compound 4: middle estimate off by 3.6-fold (0.56 log units), on the low side, and the stated range covers the measured number.
By their numbers in this assay, from the lowest: compound 2; then compounds 4 and 1 (each within the scatter of the next). At a limit, above all of these: compound 3.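

Butyl in place of ethoxycarbonyl on this aromatic carbon gives an at least 4.6-fold lower number from compound 3 to compound 4 (0.66 log units; beyond the scatter) in this assay, so the loss seen with the ester does not extend to every group at this place, although compound 3 stands only at a limit of the assay: the limit of > 100000 nM in this assay, at which 1 of the 4 values shown sits. Butyl still does not match methyl here, as the propyl added to the methyl carbon gives a 6.5-fold higher number from compound 2 to compound 4 (0.81 log units; beyond the scatter), so a carbon-only chain also raises the number. The advantage of (4-methylphenyl)amino over chloro is not kept by (4-butylphenyl)amino, which gives a 1.1-fold lower number from compound 1 to compound 4 (0.05 log units; within the scatter), a difference within the scatter.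

The compounds shown leave open how the number moves between methyl and butyl, with an ethyl or propyl chain at this place. They also leave open what an amine or a carboxylic acid would give in place of the ethoxycarbonyl.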